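Adding a methoxy to compound 2: expected effect on cytotoxicity

The source may report more compounds than this note shows. Statements on the series, on what has been measured and on what is new or still open speak of the compounds shown alone.

Compound 2 `C[S+]([O-])/C=C/c1cc(=O)c2ccccc2o1` gives 1900 nM in a functional assay on A549 cells (Homo sapiens) for cytotoxicity, with a stated time of 48 h (on this read-out lower numbers stand for stronger inhibition and higher numbers for weaker inhibition), the lowest of the three numbers, yet within the scatter of both compound 1 `COc1cccc2c(=O)cc(/C=C/[S+](C)[O-])oc12`, which gives 2200 nM, and compound 3 `CCC(=O)Oc1ccc2oc(/C=C/[S+](C)[O-])cc(=O)c2c1`, which gives 2400 nM. Compound 4 `COc1cccc2oc(/C=C/[S+](C)[O-])cc(=O)c12` differs from compound 2 by methoxy in place of hydrogen on an aromatic carbon. Within the data shown here, the only measured step that involves a methoxy, a 1.2-fold lower number from compound 1 to compound 2 (0.06 log units; within the scatter), stayed within the scatter, as did a 1.3-fold higher number from compound 2 to compound 3 (0.10 log units; within the scatter). Since a 1.2-fold lower number from compound 1 to compound 2 (0.06 log units; within the scatter) moved the number by no more than the scatter, a methoxy entering on a different aromatic carbon is not expected to do more. Compound 4 is therefore expected to show a step of a 1.1-fold higher number from compound 2 to compound 4 (0.04 log units; within the scatter) that remains within the scatter. Compound 4 is estimated at 2100 nM, with a range from 1000 nM to 4500 nM.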

Compound 4, half-maximal inhibitory concentration: 3800 nM
The estimate for compound 4 lay 1.8-fold (0.26 log units) below the measured number; the range from low to high includes it.
By their numbers in this assay, from the lowest: compounds 2, 1, 3 and 4 (each within the scatter of the next).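

In this assay, methoxy in place of hydrogen on this aromatic carbon gives a 2.0-fold higher number from compound 2 to compound 4 (0.30 log units; within the scatter), a step that reaches the edge of the scatter without passing it. With methoxy on a different aromatic carbon compound 1 gives 2200 nM and compound 4 gives 3800 nM, so these numbers alone do not establish that the position of the methoxy matters. No measurement offers an explanation for this step. As far as these compounds go, it remains open whether an amine, a carboxylic acid or a longer alkoxy chain on this carbon would give a step beyond the scatter.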